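This account rests on a few compounds, and the source may have more. Where it says the series, first, only, none or still open, it means among the compounds named here.

Of the compounds shown here, three have been measured in an assay on membranes from brain for displacement of a labelled ligand from adenosine receptor A1 (Rattus norvegicus), read by scintillation counting, with a stated time of 90 min; on this read-out higher numbers stand for weaker inhibition and lower numbers for stronger inhibition. Compound 3 `COc1cccc(/C=C/CC(=O)Nc2nc3ccccc3c(=O)s2)c1` gives 11.2 nM, the lowest of the two numbers reported. Its nearest neighbour is compound 2 `O=C(CCCc1ccccc1)Nc1nc2sccc2c(=O)s1`, which gives 35.2 nM in this assay, a gap that lies beyond the usual scatter of repeated measurements. For compound 1 `O=C(CCCc1ccc(Cl)c(Cl)c1)Nc1nc2ccccc2c(=O)s1` this assay reports only a limit, > 1500 nM, and not a number. Of the three results one is thus a limit (the limit of > 1500 nM in this assay, at which 1 of the 3 values shown sits).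

Compound 4 `O=C(C/C=C/c1cccc(Cl)c1)Nc1nc2ccccc2c(=O)s1` has not yet been measured. It differs from compound 3 in one place: chloro in place of methoxy on an aromatic carbon of a six-membered aromatic ring of carbon only, or, read one bond further out, 3-methoxyphenyl to 3-chlorophenyl. Within the data shown here, no pair among the measured compounds shows this change, so no measured step can be pointed to. The expectation is that compound 4 stays close to compound 3, with a step of a 1.4-fold higher number from compound 3 to compound 4 (0.15 log units; within the scatter) that is expected to fall within the scatter, or at most to drift slightly toward a higher number. Compound 4 is therefore estimated at 16 nM, with a range from 4 nM to 65 nM.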

Compound 4, inhibition constant: 11.4 nM
Compound 4: middle estimate off by 1.4-fold (0.15 log units), on the high side; measured number inside the range.
By their numbers in this assay, from the lowest: compounds 3 and 4 (each within the scatter of the next); then compound 2. At a limit, above all of these: compound 1.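

Among these compounds, the change from 3-methoxyphenyl to 3-chlorophenyl is the first step between two measured compounds that differ in one place, and in this assay it reads a 1.0-fold higher number from compound 3 to compound 4 (0.01 log units; within the scatter). On an aromatic carbon of a six-membered aromatic ring of carbon only, meta to a large group, this read-out therefore does not separate methoxy, with its two heavy atoms and one hydrogen-bond acceptor, from chloro, with one heavy atom and no hydrogen-bond acceptor, though this rests on a single pair. No measurement shown here speaks to why the two groups read alike.

The compounds shown leave open whether an amine, a carboxylic acid or a longer chain such as ethoxy at this place would also read like methoxy and chloro, or whether the likeness holds only for these two groups. They also leave open whether the same exchange would read alike on a saturated chain or on the core of compound 2.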